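Expected clearance of compound 4 from one measured step

A few compounds are considered here, and "the series" means these few. Any claim that something is new, unique, unknown or untested is made for them only; others in the source may bear on it.

Measured in an in vitro ADME assay on microsomes from liver (Homo sapiens) for metabolic stability, in the presence of a further agent that is not named here; on this read-out higher numbers stand for fast clearance and lower numbers for slow clearance:
- compound 1 `CC(C)(CO)CNC(=O)c1cc2cc(C#N)ccc2n1Cc1cccc(OC(F)(F)F)c1`: 20 mL.min-1.g-1
- compound 2 `Cc1ccc(Cl)cc1Cn1c(C(=O)NCC(C)(C)CO)cc2cc(C#N)ccc21`: 23 mL.min-1.g-1
- compound 3 `CC(O)CCNC(=O)c1cc2cc(C#N)ccc2n1Cc1cccc(OC(F)(F)F)c1`: < 6 mL.min-1.g-1 (a limit, not a number)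

Compound 3 is known only as a limit, < 6 mL.min-1.g-1. It stands at the limit of < 6 mL.min-1.g-1 in this assay, at which 1 of the 3 values shown sits. Its exact place on the scale of this assay is therefore unknown.

The next compound is compound 4 `CC(O)C1(CNC(=O)c2cc3cc(C#N)ccc3n2Cc2cccc(OC(F)(F)F)c2)CCCC1`. The change is a group of 8 heavy atoms (7 carbon, 1 oxygen; one five-membered non-aromatic ring of carbon only) in place of a group of 4 heavy atoms (3 carbon, 1 oxygen; no ring), on a saturated chain carbon bound to an amide-type nitrogen. It replaces the 2-hydroxypropyl group of compound 3 and leaves the rest of the molecule untouched.

Going by the values given here, one measured step bears on this place, an at least 3.3-fold lower number from compound 1 to compound 3 (0.52 log units; beyond the scatter). In that step, 2-hydroxypropyl replaced 1-(hydroxymethyl)-1-methylethyl. Among the compounds with values here, compound 2 differs elsewhere in the molecule and has no measured single-place step here, so it gives no direct guide.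

Read in reverse, the step from compound 1 suggests that moving away from 2-hydroxypropyl raises the number, although that rests on a single pair and a different incoming group. An upward change beyond the scatter is therefore expected, estimated as an at least 3.6-fold higher number from compound 3 to compound 4 (0.56 log units; beyond the scatter). For compound 4 the expected value is 22 mL.min-1.g-1, with an estimated range of 9 mL.min-1.g-1 to 55 mL.min-1.g-1.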

Compound 4, intrinsic clearance in microsomes: 9 mL.min-1.g-1
For compound 4 the middle estimate is 2.4-fold (0.39 log units) above the measured one; low and high end bracket the measured number.
By their numbers in this assay, from the lowest: compound 4; then compounds 1 and 2 (each within the scatter of the next). At a limit, below all of these: compound 3.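

In this assay, the group with the five-membered carbon ring gives a 2.2-fold lower number from compound 1 to compound 4 (0.35 log units; beyond the scatter), so at this place, on a saturated chain carbon bound to an amide-type nitrogen, a larger group carrying a ring can go with a lower number than 1-(hydroxymethyl)-1-methylethyl does. Compound 3 is known only as a limit, < 6 mL.min-1.g-1, and not as a number. The comparison with it gives an at least 1.5-fold higher number from compound 3 to compound 4 (0.17 log units; that floor lies within the scatter), and how far the ring group stands from 2-hydroxypropyl stays unsettled because compound 3 has no exact place on the scale: the limit of < 6 mL.min-1.g-1 in this assay, at which 1 of the 4 values shown sits.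

The compounds shown leave open whether the lower number of compound 4 belongs to the ring itself or to the way the hydroxyl-bearing carbon is attached to the chain. They also leave open how an amine, a carboxylic acid or a longer chain at this place would read in this assay, and whether the group of compound 4 would give a similar number on the differently substituted core of compound 2.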